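Aryl swap on the saturated ring carbon of compound 2

The source may hold more compounds than are shown below. What is called first, only, known or untested is meant among the compounds shown, and "the series" means these compounds.

Compound 1 `CCCCCCCCCCCCCCCCCCNC(=O)[C@H]1CSC(CCCCCCCCCCCC)N1` gives 8900 nM in a functional assay on DU-145 cells (Homo sapiens) for antiproliferative activity, read by sulforhodamine B assay; on this read-out lower numbers stand for stronger inhibition and higher numbers for weaker inhibition. Compound 2 `CCCCCCCCCCCCCCCCCCNC(=O)[C@H]1CSC(c2cccnc2)N1` gives 7500 nM in this assay, and compound 3 `CCCCCCCCCCCCCCCCCCNC(=O)[C@H]1CSC(c2ccc(Br)cc2)N1` gives 13800 nM. Compound 2 thus carries the lowest of the three numbers shown, though all three sit within the scatter of one another: a 1.2-fold lower number from compound 1 to compound 2 (0.07 log units; within the scatter) and a 1.8-fold higher number from compound 2 to compound 3 (0.26 log units; within the scatter), with a 1.6-fold higher number from compound 1 to compound 3 (0.19 log units; within the scatter) tying compound 1 to compound 3. Each of these steps is an exchange of the group on the saturated ring carbon, and none leaves the scatter.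

Compound 4 `CCCCCCCCCCCCCCCCCCNC(=O)[C@H]1CSC(c2c(Cl)cccc2Cl)N1` has not yet been measured. It differs from compound 2 as follows: 2,6-dichlorophenyl in place of pyridin-3-yl on a saturated ring carbon. Among the compounds with values here, the steps that bear on it are the three exchanges at the same saturated ring carbon, dodecyl to pyridin-3-yl, dodecyl to 4-bromophenyl and pyridin-3-yl to 4-bromophenyl, none of which moved this assay beyond the scatter. Another aryl at that position is therefore expected to give no step beyond the scatter, and compound 4 is estimated at 10000 nM, within 4000 nM to 25000 nM. The expected step is a 1.3-fold higher number from compound 2 to compound 4 (0.12 log units; within the scatter).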

Compound 4, half-maximal inhibitory concentration: > 20000 nM
Compound 4 gave a limit, no number; the forecaster's own chance of this, stated with the estimate: 10%; middle value at least 2.0-fold (0.30 log units) from the limit.
By their numbers in this assay, from the lowest: compounds 2, 1 and 3 (each within the scatter of the next). At a limit, above all of these: compound 4.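

At the saturated ring carbon, the group can now be seen to matter: 2,6-dichlorophenyl gives an at least 2.6-fold higher number from compound 2 to compound 4 (0.42 log units; beyond the scatter) and an at least 2.2-fold higher number from compound 1 to compound 4 (0.35 log units; beyond the scatter), whereas the exchanges among dodecyl, pyridin-3-yl and 4-bromophenyl all stayed within the scatter. Against 4-bromophenyl the reading is less firm, an at least 1.4-fold higher number from compound 3 to compound 4 (0.16 log units; that floor lies within the scatter), so that pair is not shown to be apart. Compound 4 stands at a limit, > 20000 nM, in this assay, which makes all three steps floors rather than full sizes: the limit of > 20000 nM in this assay, at which 1 of the 4 values shown sits.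

On these data alone, it remains open whether a 2-chlorophenyl or a 3,5-dichlorophenyl group at this carbon would read like compound 4 or like compound 3. Also open, as far as these compounds go, is how an aryl group carrying an amine or a carboxylic acid would read here.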